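The compounds below may be only part of what the source reports. "The series", "measured", "known", "first", "only" and "open" are said of these compounds alone.

Working notes on the series in a functional assay on L1210 cells (Mus musculus) for inhibition; a higher number here means a weaker inhibitor, a lower number a stronger inhibitor. Compound 1 `Nc1nc(O)c2ncn(C/C=C/CO)c2n1` gives 200000 nM, and compound 2 `Nc1ncnc2c1ncn2C/C=C\CCl` gives 22000 nM. Compound 2 therefore holds the lower of the two numbers and is the stronger inhibitor of this pair, with a gap beyond the usual scatter.

Compound 3 `Nc1ncnc2c1ncn2CC#CCO` has not yet been measured. It keeps the core of compound 2 and differs in the side chain: 3-hydroxyprop-1-yn-1-yl in place of 3-chloroprop-1-en-1-yl on a saturated chain carbon bound to an aromatic nitrogen. In words, 3-hydroxyprop-1-yn-1-yl stands in place of 3-chloroprop-1-en-1-yl on a saturated chain carbon bound to an aromatic nitrogen.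

Among the measured compounds shown here, no measured step covers this change, so the expectation rests on thin support. For the measured compounds named here, its only guide is compound 1, which also ends its chain in a hydroxyl and stands at 200000 nM. A moderate move towards a higher number, meaning a weaker inhibitor, is therefore expected in this assay, beyond the scatter. The estimated step is a 3.6-fold higher number from compound 2 to compound 3 (0.56 log units; beyond the scatter). For compound 3 the expected value is 80000 nM, with an estimated range of 25000 nM to 300000 nM.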

Compound 3, half-maximal inhibitory concentration: 490000 nM
Compound 3: middle estimate off by 6.1-fold (0.79 log units), on the low side; the whole stated range lies below it.
By their numbers in this assay, from the lowest: compound 2; then compound 1; then compound 3.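

Swapping 3-chloroprop-1-en-1-yl for 3-hydroxyprop-1-yn-1-yl on a saturated chain carbon bound to an aromatic nitrogen gives a 22-fold higher number from compound 2 to compound 3 (1.35 log units; beyond the scatter) in this assay and this large step is the first measured sign that inhibition in the series responds strongly to a change at this position. The heavy-atom count of the group stays the same across the step, so that count alone does not set the value here; what differs is the chain end, chlorine against hydroxyl, and the unsaturation, double bond against triple bond. Nothing available explains why the number rises on this change.

The two differences travel together in this single step, so the share of each remains unresolved; a 4-hydroxybut-2-en-1-yl or a 4-chlorobut-2-yn-1-yl chain on the same core would separate them. Also open, going by these compounds, is how the position responds to other chain ends or sizes, such as a terminal amine, a carboxylic acid or a longer chain, and whether any of these reaches a lower number than compound 2 at 22000 nM in this assay on this core.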